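A hydroxyl in place of a methyl on the sulfonyl arene

The source may report more compounds than this note shows. Statements on the series, on what has been measured and on what is new or still open speak of the compounds shown alone.

Measured compounds:
compound 1, `Cc1ccccc1S(=O)(=O)Nc1ccc(-c2nc3ccccc3o2)cc1`: > 63000 nM
compound 2, `Cc1cccc(S(=O)(=O)Nc2ccc3oc(-c4ccccc4)nc3c2)c1`: > 63000 nM

Both measured compounds were tested in an assay on isolated protein for inhibition of malate dehydrogenase, mitochondrial (Sus scrofa), with stated times of 45 min and 30 min; a lower number here means a stronger inhibitor, a higher number a weaker inhibitor. For compound 1 the value > 63000 nM is a limit of the assay, not a number. For compound 2 the value > 63000 nM is likewise a limit. Compound 1 therefore stands at the limit of > 63000 nM in this assay, at which 2 of the 2 values shown sit, and the numbers shown do not separate it from compound 2.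

Compound 3, `O=S(=O)(Nc1ccc(-c2nc3ccccc3o2)cc1)c1cccc(O)c1`, differs from compound 1 in one place: 3-hydroxyphenyl in place of 2-methylphenyl on a sulfonyl sulfur. Among the measured compounds shown here, no step between measured compounds is known, so nothing measured here tells how large such a change tends to be. Since compound 1 gives only the limit > 63000 nM, the expected step is a step that the limit leaves unreadable from compound 1 to compound 3, that is, none beyond the scatter, and compound 3 is expected to stay at or near the limit. For compound 3 the estimate is 80000 nM, with a range from 20000 nM to 300000 nM.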

Compound 3, half-maximal inhibitory concentration: > 63000 nM
Compound 3: only a limit was reported; the forecaster's own chance of this, stated with the estimate: 80%; the middle value does not contradict the limit.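

In this assay, among the compounds shown here, compound 1 and compound 3 both stand at a limit of the assay rather than at a number, so no step between them can be read: the limit of > 63000 nM in this assay, at which 3 of the 3 values shown sit. As far as these compounds go, whether 3-hydroxyphenyl in place of 2-methylphenyl on a sulfonyl sulfur changes inhibition at all stays open, as does what would bring such compounds to a readable value in this assay at all.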